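Adding one methyl to compound 3

The source may report more compounds than this note shows. Statements on the series, on what has been measured and on what is new or still open speak of the compounds shown alone.

Measured in an ADME assay on MDCK-II cells (Canis lupus familiaris) for permeability; on this read-out lower numbers stand for lower permeability and higher numbers for higher permeability:
- compound 1 `Nc1nc2c(s1)CCC[C@H]2C(=O)Nc1ccc(C[C@@H]2CC[C@H]([C@H](O)c3ccccc3)N2)cc1`: 5 10^-6 cm/s
- compound 2 `Nc1nc2c(s1)CC[C@H]2C(=O)Nc1ccc(C[C@@H]2CC[C@H]([C@H](O)c3cccnc3)N2)cc1`: < 1 10^-6 cm/s, which is a limit
- compound 3 `O=C(Nc1ccc(C[C@@H]2CC[C@H]([C@H](O)c3ccccc3)N2)cc1)[C@@H]1CCc2scnc21`: 24 10^-6 cm/s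

Of the two true numbers, compound 3 holds the higher. Compound 4 `Cc1nc2c(s1)CC[C@H]2C(=O)Nc1ccc(C[C@@H]2CC[C@H]([C@H](O)c3ccccc3)N2)cc1` differs from compound 3 by methyl in place of hydrogen on an aromatic carbon. Among the measured compounds shown here, only one measured step bears on this change, a 4.8-fold higher number from compound 1 to compound 3 (0.68 log units; beyond the scatter), and it exchanged a whole group on a carbonyl carbon. A single methyl in place of hydrogen on an aromatic carbon is a much smaller change, so no shift beyond the scatter is expected in this assay. The expected step is a 1.1-fold lower number from compound 3 to compound 4 (0.04 log units; within the scatter). For compound 4 the estimated value is 22 10^-6 cm/s, with an expected range of 10 10^-6 cm/s to 42 10^-6 cm/s.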

Compound 4, apparent permeability: 26 10^-6 cm/s
Beside the measured number, compound 4's estimate is 1.2-fold (0.07 log units) below it; low and high end bracket the measured number.
By their numbers in this assay, from the lowest: compound 1; then compounds 3 and 4 (each within the scatter of the next). At a limit, below all of these: compound 2.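

In this assay, methyl in place of hydrogen on an aromatic carbon, next to the ring nitrogen and next to the ring sulfur, gives a 1.1-fold higher number from compound 3 to compound 4 (0.03 log units; within the scatter) and so stays within the scatter. With this methyl present, the exchange of the whole group on the carbonyl carbon still gives a 5.2-fold higher number from compound 1 to compound 4 (0.72 log units; beyond the scatter) and stays beyond the scatter. Nothing measured here gives a cause for either step. The compounds shown leave open how an ethyl group, a methoxy group or a longer chain on this aromatic carbon would read in this assay for this series.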